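8-Hydroxyquinolin-2-yl in place of pyridin-2-yl

A few compounds are considered here, and "the series" means these few. Any claim that something is new, unique, unknown or untested is made for them only; others in the source may bear on it.

Within the data shown here, in a functional assay on DU-145 cells (Homo sapiens) for inhibition, read by trypan blue exclusion, with a stated time of 72 h (a lower number here means a stronger inhibitor, a higher number a weaker inhibitor), compound 2 (`Cn1c(=O)c(S(=O)(=O)c2ccc(F)cc2F)cc2cnc(Nc3ccccn3)nc21`) gives 75000 nM, the highest of the two numbers so far, while compound 1 (`Cn1c(=O)c(S(=O)(=O)c2ccc(F)cc2F)cc2cnc(Nc3ccc4[nH]ncc4c3)nc21`) gives 30000 nM. Compound 3 (`Cn1c(=O)c(S(=O)(=O)c2ccc(F)cc2F)cc2cnc(Nc3ccc4cccc(O)c4n3)nc21`) carries 8-hydroxyquinolin-2-yl in place of pyridin-2-yl on a nitrogen on an aromatic ring. Among the measured compounds shown here, only one measured step bears on this place: a 2.5-fold higher number from compound 1 to compound 2 (0.40 log units; beyond the scatter), a modest change on replacing 1H-indazol-5-yl with pyridin-2-yl. On that single step, a modest move to a lower number is expected, a 2.5-fold lower number from compound 2 to compound 3 (0.40 log units; beyond the scatter). The estimated value for compound 3 is 30000 nM, with an expected range of 8000 nM to 90000 nM.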

Compound 3, half-maximal inhibitory concentration: 5000 nM
Beside the measured number, compound 3's estimate is 6.0-fold (0.78 log units) above it; the measured number lies below the stated range.
By their numbers in this assay, from the lowest: compound 3; then compound 1; then compound 2.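

The group on the nitrogen on an aromatic ring can move the number further than the earlier pair showed: 8-hydroxyquinolin-2-yl gives a 15-fold lower number from compound 2 to compound 3 (1.18 log units; beyond the scatter), and against the indazole it gives a 6.0-fold lower number from compound 1 to compound 3 (0.78 log units; beyond the scatter). With both steps beyond the scatter, compound 3 is the strongest inhibitor of the three. Nothing available explains this gain.

The compounds shown do not separate the contribution of the hydroxy group from that of the second ring. As far as these compounds go, what an amine or a methoxy group in place of the hydroxy would give also stays open.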